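Swapping the benzyl group while the core stays fixed

The source may report more compounds than this note shows. Statements on the series, on what has been measured and on what is new or still open speak of the compounds shown alone.

The measurements come from a toxicity assay on NIH3T3 cells (Mus musculus) for cytotoxicity, read by resazurin assay; on this read-out lower numbers stand for an effect already at smaller amounts and higher numbers for an effect only at larger amounts of compound.
Compound 1, `COC(=O)c1ccc(NCc2cncn2Cc2ccccc2F)cc1-c1ccccc1`: "not determined" (no result reported).
Compound 2, `Nc1cc(-c2ccccc2)ccc1Cn1cncc1CNc1ccc(-c2nc3ccccc3s2)c(-c2ccccc2)c1`: > 1000 nM, a limit of the assay.
Compound 3, `CN(C)C(=O)c1ccc(NCc2cncn2Cc2ccc(-c3ccccc3)cc2)cc1-c1ccccc1`: > 1000 nM, again a limit of the assay.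

For compound 1 no number exists in this assay. Of the three entries shown, two sit at the limit of > 1000 nM in this assay, at which 2 of the 3 values shown sit, so no step between measured compounds can be drawn. Compound 4, `COC(=O)c1ccc(NCc2cncn2Cc2cccc(C(C)(C)C)c2)cc1-c1ccccc1`, differs from compound 1 by 3-(tert-butyl)phenyl in place of 2-fluorophenyl on a saturated chain carbon bound to an aromatic nitrogen. Among the compounds with values here, with no measured step to lean on, nothing beyond the usual scatter is expected from this change in this assay, and the most likely outcome for compound 4 is once more a limit rather than a number. Compound 4 is therefore estimated to give 2000 nM, with a range from 700 nM to 10000 nM.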

Compound 4, half-maximal effective concentration: > 1000 nM
Compound 4: no number, only a limit; the forecaster's own chance of this, stated with the estimate: 75%; the middle value does not contradict the limit.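

Compound 4 gives > 1000 nM in this assay, which is a limit and not a number. Within the data shown here, compound 1 has no number there, so no step between compound 1 and compound 4 can be read. The compounds shown leave open what swapping the benzyl group does to this read-out, as one entry keeps recurring: the limit of > 1000 nM in this assay, at which 3 of the 4 values shown sit.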